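A few compounds are considered here, and "the series" means these few. Any claim that something is new, unique, unknown or untested is made for them only; others in the source may bear on it.

Three compounds share one core and differ only in the ring at the end of one arm. Compound 1 `COC(=O)/C=C/c1cccc(N(Cc2ccc(/C=C/c3cccc(C(F)(F)F)c3)cc2)C(=O)NC(C)C)c1` gives 932 nM in an assay on isolated protein with Bile acid receptor (Homo sapiens) as the target; a higher number here means that more compound is needed for the effect, a lower number that less compound is needed. Compound 2 `COC(=O)/C=C/c1cccc(N(Cc2ccc(/C=C/c3c(C)cc(C)cc3C)cc2)C(=O)NC(C)C)c1` gives 431 nM in this assay, and compound 3 `COC(=O)/C=C/c1cccc(N(Cc2ccc(/C=C/c3ccc(F)cc3)cc2)C(=O)NC(C)C)c1` gives 348 nM. Exchanging that ring brought a 2.2-fold lower number from compound 1 to compound 2 (0.33 log units; beyond the scatter) and a 2.7-fold lower number from compound 1 to compound 3 (0.43 log units; beyond the scatter), while a 1.2-fold lower number from compound 2 to compound 3 (0.09 log units; within the scatter). Compound 3 therefore holds the lowest number of the three, although its gap to compound 2 stays within the scatter and only its gap to compound 1 lies beyond it.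

Compound 4 `COC(=O)/C=C/c1cccc(N(Cc2ccc(-c3cccc(OC)c3)cc2)C(=O)NC(C)C)c1` has not been measured. It differs from compound 3 in one place: 3-methoxyphenyl in place of 2-(4-fluorophenyl)ethenyl on an aromatic carbon. Within the data shown here, none of the measured steps bears directly on this change; all three swapped one distal ring for another while keeping the ethenyl link in place, whereas here the link itself is removed and a ring bearing a methoxy group is attached directly. The ring swaps that were measured were modest at most, which suggests no large swing in either direction, though the removal of the link adds uncertainty. Compound 4 is expected to give about 500 nM in this assay, within 150 nM to 2000 nM. That estimate means a 1.4-fold higher number from compound 3 to compound 4 (0.16 log units; within the scatter) is expected, a step not beyond the scatter.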

Compound 4, half-maximal effective concentration: 1370 nM
The estimate for compound 4 lay 2.7-fold (0.44 log units) below the measured number, within the range that was stated.
By their numbers in this assay, from the lowest: compounds 3 and 2 (each within the scatter of the next); then compounds 1 and 4 (each within the scatter of the next).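

Exchanging the 2-(4-fluorophenyl)ethenyl arm for a directly attached 3-methoxyphenyl gives a 3.9-fold higher number from compound 3 to compound 4 (0.60 log units; beyond the scatter) in this assay and the same kind of exchange from the 2,4,6-trimethylphenyl arm gives a 3.2-fold higher number from compound 2 to compound 4 (0.50 log units; beyond the scatter) beyond the scatter, whereas every earlier step kept the ethenyl link and swapped only the ring. Loss of the link therefore need not leave the number unchanged at this position, yet the result depends on the reference compound, since the exchange from the 3-(trifluoromethyl)phenyl arm gives a 1.5-fold higher number from compound 1 to compound 4 (0.17 log units; within the scatter) and so shows no clear difference. No measurement available here explains these steps.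

Each exchange removes the ethenyl link and changes the ring substituent at once, so the share of each in the steps stays unresolved. A 2-(3-methoxyphenyl)ethenyl arm or a directly attached 4-fluorophenyl would help to separate the two changes, while a 2-(4-fluorophenyl)ethyl arm would test a saturated two-carbon link in place of the double bond.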